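Replacing a Carbonyl Group in Compound 3

A few compounds are considered here, and "the series" means these few. Any claim that something is new, unique, unknown or untested is made for them only; others in the source may bear on it.

- Compound 1 `CCN(CC)CCCNC(=O)c1ccc(C(CC)(CC)c2ccc(OCC(O)C(C)(C)C)c(C)c2)n1CC`: 1800 nM
- Compound 2 `C=CCN(C)C(=O)c1ccc(C(CC)(CC)c2ccc(OCC(O)C(C)(C)C)c(C)c2)n1CC`: > 50000 nM
- Compound 3 `CC[C@@H](C)[C@H](NC(=O)c1ccc(C(CC)(CC)c2ccc(OCC(=O)C(C)(C)C)c(C)c2)n1CC)C(=O)O`: 4500 nM

In a functional assay on Caco-2 cells (Homo sapiens), read by MTT assay, with a stated time of 48 h (on this read-out higher numbers stand for weaker inhibition and lower numbers for stronger inhibition), compound 3 stands at 4500 nM, a higher number than compound 1 at 1800 nM, and that gap lies beyond the scatter. Compound 2 reads > 50000 nM, which is a limit of the assay and not a number.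

Compound 4 `CC[C@@H](C)[C@H](NC(=O)c1ccc(C(CC)(CC)c2ccc(OCC(O)C(C)(C)C)c(C)c2)n1CC)C(=O)O` differs from compound 3 in one place: 1-hydroxy-2,2-dimethylpropyl in place of (tert-butyl)carbonyl on a saturated chain carbon bound to an oxygen on an aromatic ring. Going by the values given here, the only measured step, an at least 27-fold higher number from compound 1 to compound 2 (1.44 log units; beyond the scatter), is a change on a carbonyl carbon and a different one, so it gives no size for this change. Among the compounds with values here, compounds 1 and 2 both carry the 2-hydroxy-3,3-dimethylbutoxy group, so no measured pair isolates it. Compound 3 at 4500 nM is therefore the best anchor, and no step beyond the scatter is expected in this assay, though with wide uncertainty. The expected step is a 1.1-fold higher number from compound 3 to compound 4 (0.05 log units; within the scatter). For compound 4 the estimated value is 5000 nM, with an expected range from 1700 nM to 18000 nM.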

Compound 4, half-maximal inhibitory concentration: 3400 nM
The estimate for compound 4 lay 1.5-fold (0.17 log units) above the measured number, within the range that was stated.
By their numbers in this assay, from the lowest: compounds 1, 4 and 3 (each within the scatter of the next, the first and the last beyond it). At a limit, above all of these: compound 2.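

In this assay, a 1.3-fold lower number from compound 3 to compound 4 (0.12 log units; within the scatter), so on this saturated chain carbon bound to an oxygen on an aromatic ring, the two groups are not told apart. Changing the amide side gives a 1.9-fold higher number from compound 1 to compound 4 (0.28 log units; within the scatter), which does not separate 1-carboxy-2-methylbutyl from 3-(diethylamino)propyl, whereas replacing allyl(methyl)amino gives an at least 14-fold lower number from compound 2 to compound 4 (1.16 log units; beyond the scatter). That larger step has only a lower bound, since compound 2 stands at a limit and not a number: the limit of > 50000 nM in this assay, at which 1 of the 4 values shown sits.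

On these data alone, what a carboxylic acid or an amine would give in place of 1-hydroxy-2,2-dimethylpropyl on this chain carbon stays open.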